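Vinyl to ethyl on the sulfonyl of compound 2

This account rests on a few compounds, and the source may have more. Where it says the series, first, only, none or still open, it means among the compounds named here.

Notes on the series. Compound 1 `C=CS(=O)(=O)N1CCN(c2ncnc3sc(-c4ccccc4)cc23)CC1` gives 21100 nM in a functional assay on MDA-MB-436 cells (Homo sapiens) for antiproliferative activity, read by MTT assay, with a stated time of 48 h; on this read-out higher numbers stand for weaker inhibition and lower numbers for stronger inhibition. Compound 2 `C=CS(=O)(=O)N1CCN(c2ncnc3sc(-c4ccc(N5CCN(C)CC5)cc4)cc23)CC1` gives 8760 nM in this assay, the second highest number of the three, and compound 3 `C=CS(=O)(=O)N1CCN(c2nc(OC[C@H]3CCCN3C)nc3sc(-c4ccc(N5CCN(C)CC5)cc4)cc23)CC1` gives 540 nM. The steps measured so far are a 2.4-fold lower number from compound 1 to compound 2 (0.38 log units; beyond the scatter) and a 16-fold lower number from compound 2 to compound 3 (1.21 log units; beyond the scatter); both are changes on aromatic carbons of the shared core and its aryl substituent, not at the sulfonyl group.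

Compound 4 `CCS(=O)(=O)N1CCN(c2ncnc3sc(-c4ccc(N5CCN(C)CC5)cc4)cc23)CC1` differs from compound 2 by ethyl in place of vinyl on a sulfonyl sulfur. Among the compounds with values here, neither measured step touches this place, so no step in the set bears on it directly; the only information is that the double bond outside aromatic rings leaves and a saturated two-carbon chain enters. Within the data shown here, with no step at this position to lean on, the working expectation is a modest shift to a higher number, and for compound 4 a step of a 1.9-fold higher number from compound 2 to compound 4 (0.29 log units; within the scatter) is estimated. Compound 4 is therefore expected to give about 17000 nM in this assay, within a range of 6000 nM to 50000 nM, the range kept wide since no measured change informs this position.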

Compound 4, half-maximal inhibitory concentration: 10600 nM
Compound 4: middle estimate off by 1.6-fold (0.21 log units), on the high side; the measured number falls inside the stated range.
By their numbers in this assay, from the lowest: compound 3; then compounds 2, 4 and 1 (each within the scatter of the next, the first and the last beyond it).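

Ethyl in place of vinyl on the sulfonyl sulfur gives a 1.2-fold higher number from compound 2 to compound 4 (0.08 log units; within the scatter) in this assay, so with the rest of compound 2 held fixed, this read-out does not separate the two groups. Within the data shown here, this is the first reading at the sulfonyl group, as both earlier steps lie on aromatic carbons, and it shows that here the double bond outside aromatic rings can give way to a saturated chain of the same heavy-atom count without a change beyond the scatter. No measurement is at hand that would explain this result.

Going by these compounds, it remains open whether the same holds when (1-methylpyrrolidin-2-yl)methoxy is also present on the shared core, since this change has been read only with the rest of compound 2, not with the rest of compound 3. Also open, on these data alone, is how this assay would respond at the same sulfonyl sulfur to a longer chain such as n-butyl, to a ring such as cyclopropyl, or to a group carrying an amine.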